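Solubility notes on the shared-core series, compounds 1 to 4

The source may report more compounds than this note shows. Statements on the series, on what has been measured and on what is new or still open speak of the compounds shown alone.

Measured compounds, all in a physicochemical assay for solubility, at pH 7; a higher number here means a more soluble compound, a lower number a less soluble compound:

Compound 1 `CNC(=O)c1cc(Oc2ccc3nc(Nc4cccc(Cl)c4)ncc3c2)ccn1`. In this assay compound 1 gives < 1000 nM, which is a limit of the assay and not a number.
Compound 2 `CNC(=O)c1cc(Oc2ccc3nc(Nc4cccc(OC(F)(F)F)c4)ncc3c2)ccn1`. In this assay compound 2 gives < 1000 nM, again a limit.
Compound 3 `CNC(=O)c1cc(Oc2ccc3nc(Nc4ccc(Br)cc4)ncc3c2)ccn1`. In this assay compound 3 gives < 1000 nM, also a limit.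

Compound 3 therefore stands at the assay limit, as do the other two; (the limit of < 1000 nM in this assay, at which 3 of the 3 values shown sit).

Compound 4 is `CNC(=O)c1cc(Oc2ccc3nc(Nc4ccc(C(F)(F)F)cc4)ncc3c2)ccn1`. Relative to compound 3 the change is trifluoromethyl in place of bromo on an aromatic carbon.

Within the data shown here, three measured steps bear on the question of how a change on the aryl ring of the amine moves this read-out, but none can be sized: a step that the two limits leave unreadable from compound 1 to compound 2; a step that the two limits leave unreadable from compound 1 to compound 3; a step that the two limits leave unreadable from compound 2 to compound 3. Every value sits at the same limit, so no direction and no size beyond the scatter can be read from them.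

With nothing pointing away from the limit, compound 4 is expected to remain near it, with an estimated 500 nM (range 100 nM to 2000 nM), an expected step that the limit leaves unreadable from compound 3 to compound 4 from compound 3.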

Compound 4, solubility: < 1000 nM
Compound 4 was reported as a limit; the forecaster's own chance of this, stated with the estimate: 80%; the middle value lies beyond the limit too.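

Compound 4 joins compounds 1, 2 and 3 at a limit in this assay, so no step among these four compounds can be read: the limit of < 1000 nM in this assay, at which 4 of the 4 values shown sit.

The compounds shown leave open how far each lies from that limit, and whether any change on the aryl ring of the amine moves the read-out.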